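This account rests on a few compounds, and the source may have more. Where it says the series, first, only, none or still open, it means among the compounds named here.

Measured in a functional assay on MCF7 cells (Homo sapiens) for antiproliferative activity, read by MTT assay, with a stated time of 72 h; on this read-out lower numbers stand for stronger inhibition and higher numbers for weaker inhibition:
- compound 1 `O=C1COc2ccc(-c3cccc(NS(=O)(=O)c4ccc(F)cc4)c3)cc2N1C1CC1`: > 40000 nM
- compound 2 `O=C1COc2ccc(-c3cccc(NS(=O)(=O)c4ccc(F)cc4)c3)cc2N1C1CCCCC1`: 21400 nM

Compound 1 gives > 40000 nM, which is a limit of the assay and not a number. For the measured compounds named here, compound 2, at 21400 nM, is the only compound with a number in this assay. Compound 3 `Cc1ccc(N2C(=O)COc3ccc(-c4cccc(NS(=O)(=O)c5ccc(F)cc5)c4)cc32)cc1` carries 4-methylphenyl in place of cyclohexyl on an amide-type nitrogen in a ring. Going by the values given here, the sole measured step at this nitrogen is an at least 1.8-fold lower number from compound 1 to compound 2 (0.27 log units; that floor lies within the scatter), and it rests on (the limit of > 40000 nM in this assay, at which 1 of the 2 values shown sits). It gives no ground for expecting a step beyond the scatter in this assay. The expected step is a 1.2-fold lower number from compound 2 to compound 3 (0.08 log units; within the scatter). For compound 3 the estimate is 18000 nM, with an expected range of 6000 nM to 40000 nM.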

Compound 3, half-maximal inhibitory concentration: 32100 nM
Compound 3: middle estimate off by 1.8-fold (0.25 log units), on the low side; the range from low to high includes it.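

At this nitrogen, this assay shows a 1.5-fold higher number from compound 2 to compound 3 (0.18 log units; within the scatter) when the non-aromatic cyclohexyl gives way to the aromatic 4-methylphenyl, so aromatic and non-aromatic six-membered carbon rings are not told apart here. The comparison with cyclopropyl gives an at least 1.2-fold lower number from compound 1 to compound 3 (0.09 log units; that floor lies within the scatter) as its only reading, a floor and not a measured size: the limit of > 40000 nM in this assay, at which 1 of the 3 values shown sits.

Still open, as far as these compounds go, is whether an amine or a carboxylic acid on this nitrogen, or a longer chain such as n-hexyl, would give a step beyond the scatter. All three values also leave open whether any group here brings the series to strong inhibition.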